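A few compounds are considered here, and "the series" means these few. Any claim that something is new, unique, unknown or untested is made for them only; others in the source may bear on it.

Measured compounds:
Compound 1 `Cc1nc2c3ccccc3ccc2c2nc3c(ccc4ccccc43)c(-c3cccc([N+](=O)[O-])c3)c12` — 117 ug/mL
Compound 2 `Cc1ccc(-c2c3ccc4ccccc4c3nc3c2c(C)nc2c4ccccc4ccc32)cc1` — 123 ug/mL

In a functional assay, read by spectrophotometry, with a stated time of 30 min (a lower number here means a stronger inhibitor, a higher number a weaker inhibitor), compound 1 gives 117 ug/mL, and compound 2 gives 123 ug/mL. Compound 2 stands at the top of these two numbers, but the step of a 1.1-fold higher number from compound 1 to compound 2 (0.02 log units; within the scatter) is within the scatter, so the two values cannot be told apart.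

Compound 3 `Cc1nc2c3ccccc3ccc2c2nc3c(ccc4ccccc43)c(C)c12` differs from compound 2 by methyl in place of 4-methylphenyl on an aromatic carbon. For the measured compounds named here, the only measured step, a 1.1-fold higher number from compound 1 to compound 2 (0.02 log units; within the scatter), exchanges one substituted phenyl ring for another on the same aromatic carbon and leaves the number essentially unchanged. Going by the values given here, no measured step removes the aromatic ring from that position altogether, so the effect of the change to compound 3 is not covered by the data. On the evidence available, the expected step of a 1.0-fold lower number from compound 2 to compound 3 (0.01 log units; within the scatter) is none beyond the scatter, with a wider range to reflect the uncovered change. Compound 3 is therefore estimated at 120 ug/mL, between 55 ug/mL and 260 ug/mL.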

Compound 3, half-maximal inhibitory concentration: 129 ug/mL
Compound 3: the middle estimate sits 1.1-fold (0.03 log units) below what was measured, and the stated range covers the measured number.
By their numbers in this assay, from the lowest: compounds 1, 2 and 3 (each within the scatter of the next).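

In this assay, the six-membered aromatic ring on this carbon, opposite the ring nitrogen, gives way to methyl in two comparisons: a 1.0-fold higher number from compound 2 to compound 3 (0.02 log units; within the scatter) with methyl in place of 4-methylphenyl, and a 1.1-fold higher number from compound 1 to compound 3 (0.04 log units; within the scatter) with methyl in place of 3-nitrophenyl. For the compounds shown here, the earlier pair showed only that one substituted phenyl ring could be exchanged for another without a step beyond the scatter; these steps extend that to losing the ring altogether, leaving a single methyl. Nothing available explains this lack of a readable difference.

What an amine, a carboxylic acid or a longer chain would do at this position remains open, as all three groups shown here lack hydrogen-bond donors and acceptors or, for 3-nitrophenyl, differ from them only by the nitro group. The compounds also leave open whether a change elsewhere on the shared core, such as at its other methyl, would move the number beyond the scatter.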